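This account rests on a few compounds, and the source may have more. Where it says the series, first, only, none or still open, it means among the compounds named here.

Compound 1, `CCCc1cc(N)c2cc(NC(=O)/C=C/c3ccc(O)cc3)ccc2n1`, is the weaker of the two compounds with numbers in an assay on isolated protein for displacement of a labelled ligand from melanin-concentrating hormone receptor 1 (Homo sapiens); on this read-out lower numbers stand for stronger inhibition and higher numbers for weaker inhibition. Compound 1 gives 1100 nM, the highest of the two values, whereas compound 2, `CCCc1cc(N)c2cc(NC(=O)C3CCC(c4ccc(Cl)cc4)CC3)ccc2n1`, gives 4.4 nM in this assay. Compound 2 differs from compound 1 in more than one place, so the gap between them says nothing about any single change. Compound 3, `CCCCc1ccc(/C=C/C(=O)Nc2ccc3nc(CCC)cc(N)c3c2)cc1`, is not yet measured and departs from compound 1 by a single change: butyl in place of hydroxy on an aromatic carbon. Within the data shown here, no measured pair shows what this change does in this assay, so the direction has to be estimated without a directly comparable step. A moderate gain is expected, with the step of a 2.8-fold lower number from compound 1 to compound 3 (0.44 log units; beyond the scatter) taken as a modest move rather than a large one, since nothing in the measured pair ties the change to the drop seen for compound 2. Compound 3 is expected to give about 400 nM, within a range from 100 nM to 1500 nM.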

Compound 3, half-maximal inhibitory concentration: 45 nM
The estimate for compound 3 lay 8.9-fold (0.95 log units) above the measured number, outside the stated range (below it).
By their numbers in this assay, from the lowest: compound 2; then compound 3; then compound 1.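

In this assay, putting butyl in place of hydroxy on this aromatic carbon, para to a large group, gives a 24-fold lower number from compound 1 to compound 3 (1.39 log units; beyond the scatter). Among these compounds, this is the first comparison here that isolates one change, and it shows that this position responds strongly to what it carries. It also shows that a compound without the hydroxy can bind far more strongly, so that group is not needed for a number in this range. No measurement at hand explains the drop, so the removal of hydroxy and the arrival of butyl cannot be separated as its source.

The compounds shown leave open whether a shorter group such as methyl, an ether such as methoxy, or a longer chain such as hexyl would do as well here. They also leave open whether butyl would bring a similar gain on a different amide side chain.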